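A few compounds are considered here, and "the series" means these few. Any claim that something is new, unique, unknown or untested is made for them only; others in the source may bear on it.

The study compares two measured compounds and asks what a third will do. Compound 1, `O=C(/C(=N/O)Nc1ccc(F)c(Br)c1)C1CCN(C(=O)NCc2ccccc2)CC1`, carries a large group on its saturated ring and, in an assay for inhibition of Indoleamine 2,3-dioxygenase 1 (Homo sapiens), with a stated time of 1 h (a higher number here means a weaker inhibitor, a lower number a stronger inhibitor), compound 1 gives 43 nM. Compound 2, `O=C(/C(=N/O)Nc1ccc(F)c(Br)c1)C1CCCCC1`, keeps the same core but with a bare saturated carbon ring; in this assay compound 2 gives 132 nM, the higher of the two numbers, and the gap to compound 1 lies beyond the usual scatter. Compound 3, `NS(=O)(=O)NC[C@H]1CC[C@H](C(=O)/C(=N/O)Nc2ccc(F)c(Br)c2)CC1`, takes compound 2 one step further: (sulfamoylamino)methyl in place of hydrogen on a saturated ring carbon. Among the compounds with values here, no measured pair shows exactly this change, so the direction is read only from the two values at hand. Since compound 1, which also bears a large group on the saturated ring, gives the lower number 43 nM, the step from compound 2 to compound 3 is expected to bring a lower number, estimated at a 6.6-fold lower number from compound 2 to compound 3 (0.82 log units; beyond the scatter). For compound 3 the expected value in this assay is 20 nM, with a range from 5 nM to 80 nM.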

Compound 3, half-maximal inhibitory concentration: 198 nM
Beside the measured number, compound 3's estimate is 9.9-fold (1.00 log units) below it, outside the stated range (above it).
By their numbers in this assay, from the lowest: compound 1; then compounds 2 and 3 (each within the scatter of the next).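

In this assay the exchange of hydrogen for (sulfamoylamino)methyl on a saturated ring carbon, three ring bonds from the ring atom that bears a large group, gives a 1.5-fold higher number from compound 2 to compound 3 (0.18 log units; within the scatter) and so leaves the number unchanged within the scatter. Within the data shown here, this shows that adding this group at this ring carbon does not by itself separate compound 3 from compound 2, which the earlier compounds could not show. Nothing among the data shown accounts for this result.

As far as these compounds go, whether an aminomethyl group or a carboxylic acid at the same ring carbon would also stay within the scatter of compound 2 remains open. So does whether a longer chain ending in the sulfamoylamino group would shift the number in this position.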